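Dienamide series: ethyl for methyl on the piperazine nitrogen

The source may report more compounds than this note shows. Statements on the series, on what has been measured and on what is new or still open speak of the compounds shown alone.

Compound 1 `CCNC(=O)/C=C/C=C/[C@H](O)Cc1ccc(OC)c(OC)c1`: 9430 nM
Compound 2 `COc1ccc(C[C@@H](O)/C=C/C=C/C(=O)NCc2ccc(Cl)cc2)cc1OC`: 15700 nM
Compound 3 `COc1ccc(C[C@@H](O)/C=C/C=C/C(=O)N2CCN(C)CC2)cc1OC`: 18900 nM

In a functional assay on IMR-32 cells (Homo sapiens) for antiproliferative activity, read by sulforhodamine B assay, with a stated time of 48 h (a lower number here means a stronger inhibitor, a higher number a weaker inhibitor), compound 3 gives the highest of the three numbers, yet its steps to the others lie within the scatter: a 2.0-fold higher number from compound 1 to compound 3 (0.30 log units; within the scatter) and a 1.2-fold higher number from compound 2 to compound 3 (0.08 log units; within the scatter). Compound 4 `CCN1CCN(C(=O)/C=C/C=C/[C@H](O)Cc2ccc(OC)c(OC)c2)CC1` differs from compound 3 only by methyl in place of hydrogen on a saturated chain carbon bound to an amine nitrogen in a ring. For the measured compounds named here, no measured step changes a group at this place. The nearest comparison is a change of an amide substituent, a 1.7-fold higher number from compound 1 to compound 2 (0.22 log units; within the scatter), also within the scatter, and all amide variations here leave this assay unchanged. Compound 4 is therefore expected to give 19000 nM (range 9000 nM to 40000 nM), an estimated step of a 1.0-fold higher number from compound 3 to compound 4 (0.00 log units; within the scatter), not beyond the scatter.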

Compound 4, half-maximal inhibitory concentration: 10800 nM
Beside the measured number, compound 4's estimate is 1.8-fold (0.25 log units) above it; measured number inside the range.
By their numbers in this assay, from the lowest: compounds 1, 4, 2 and 3 (each within the scatter of the next).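

In this assay, for the compounds shown here, the change from 4-methylpiperazin-1-yl to 4-ethylpiperazin-1-yl is the only measured step at this place, and the added methyl stays within the scatter (a 1.8-fold lower number from compound 3 to compound 4 (0.24 log units; within the scatter)). The 4-ethylpiperazin-1-yl amide also stays within the scatter of the two open-chain amides (a 1.5-fold lower number from compound 2 to compound 4 (0.16 log units; within the scatter); a 1.1-fold higher number from compound 1 to compound 4 (0.06 log units; within the scatter)), so no amide shown separates from the others. No measurement here offers an explanation for these numbers.

Still open, as far as these compounds go, is whether a longer chain such as propyl, or a 2-hydroxyethyl group, in place of this ethyl would give a step beyond the scatter.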